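The source may report more compounds than this note shows. Statements on the series, on what has been measured and on what is new or still open speak of the compounds shown alone.

In a physicochemical assay for lipophilicity, in phosphate buffer, measured as octanol-water partition, at pH 11.5 (a lower number here means a more polar compound, a higher number a more lipophilic compound), compound 1 (`CCCCCCCCNC(=N)NC(=N)Nc1ccc(C)cc1`) gives 4.93, and compound 2 (`CCCCOC(=N)NC(=N)Nc1ccc(Cl)cc1`) gives 3.32. Compound 2 is the lower of the two numbers, and the gap between them lies beyond the scatter. The next compound to be measured is compound 3 (`CCCCCCCCCCOC(=N)NC(=N)Nc1ccc(Cl)cc1`). It carries hexyl in place of hydrogen on a saturated chain carbon, four bonds along the chain from an oxygen on an unsaturated carbon. Among the compounds with values here, the series holds no measured step between compounds that differ in one place, so the expectation rests on the size of this structural change alone. A large upward shift in this assay is expected, well beyond the scatter. The estimated step is a number 2.68 log units higher from compound 2 to compound 3 (beyond the scatter). For compound 3 the expected value is 6, with an estimated range of 5.2 to 6.8.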

Compound 3, partition coefficient: 6.32
Beside the measured number, compound 3's estimate is 0.32 log units below it, within the range that was stated.
By their numbers in this assay, from the lowest: compound 2; then compound 1; then compound 3.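

In this assay, within the data shown here, hexyl in place of hydrogen on a saturated chain carbon, four bonds along the chain from an oxygen on an unsaturated carbon, gives a number 3.00 log units higher from compound 2 to compound 3 (beyond the scatter) and supplies the first step between compounds that differ in one place. This chain position therefore responds strongly to the addition of hexyl, at least on the core shared by this pair. Nothing at hand accounts for the size of this step.

From the compounds shown here alone, a single step does not show how the number follows chain length, so it remains open whether a methyl addition, a longer chain or a chain ending in an amine or a carboxylic acid at this position would shift it in proportion. Also open, going by these compounds, is whether a step of this size carries over to the core of compound 1.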